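Adding a Methoxycarbonyl Group: Does the Step Repeat?

The compounds below may be only part of what the source reports. "The series", "measured", "known", "first", "only" and "open" are said of these compounds alone.

Compound 2 `CN(C)C(=O)c1ccc2cccccc1-2` and compound 1 `COC(=O)c1ccc2ccc(C(=O)N(C)C)c-2cc1` differ in one place, (methoxycarbonyl in place of hydrogen on an aromatic carbon). In a physicochemical assay for lipophilicity, read by HPLC, measured as octanol-water partition, at pH 11 (on this read-out higher numbers stand for higher lipophilicity and lower numbers for lower lipophilicity), compound 2 gives 1.6 and compound 1 gives 2.1, so a number 0.50 log units higher from compound 2 to compound 1 (beyond the scatter). Compound 3 `CN(C)C(=O)c1cn(C)c2ccccc12` rests on a different core; how the two cores differ is not broken down here. In this assay compound 3 gives 1.3. Compound 4 `COC(=O)c1ccc2c(C(=O)N(C)C)cn(C)c2c1` is not yet measured and arises from compound 3 by methoxycarbonyl in place of hydrogen on an aromatic carbon. This is the same kind of change, not the same: in compound 1 the group sits on a seven-membered aromatic ring of carbon only, in compound 4 on a six-membered aromatic ring of carbon only, meta to a fused ring and para to a fused ring. In this assay an expected step of a number 0.50 log units higher from compound 3 to compound 4 (beyond the scatter) rests on the earlier one because a number 0.50 log units higher from compound 2 to compound 1 (beyond the scatter). Compound 4 is therefore estimated at 1.8, with a likely range from 1.4 to 2.2.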

Compound 4, distribution coefficient: 1.9
Estimate against measurement, compound 4: 0.10 log units below; the range from low to high includes it.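

In this assay putting methoxycarbonyl in place of hydrogen gives a number 0.60 log units higher from compound 3 to compound 4 (beyond the scatter) and, on the other core, a number 0.50 log units higher from compound 2 to compound 1 (beyond the scatter) so the two steps run the same way. For the compounds shown here, this is only one pair of cores, with the group on a six-membered aromatic ring in compound 4 and on a seven-membered aromatic ring in compound 1, so it shows agreement here and no general rule for other cores. Nothing measured here explains the size of either step.

The compounds shown leave open whether a carboxylic acid or an amine in the same place would also give matching steps on both cores. They also leave open whether the step would hold with methoxycarbonyl elsewhere on these rings.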